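Does an aromatic ring shorten the half-life again?

The compounds below may be only part of what the source reports. "The series", "measured", "known", "first", "only" and "open" are said of these compounds alone.

Measured in an ADME assay on microsomes from liver (Rattus norvegicus) for metabolic stability; on this read-out lower numbers stand for a shorter-lived compound and higher numbers for a longer-lived compound:
- Compound 1 `CC(C)C(Cc1ncc[nH]1)c1ccc(-c2ccc3cccc(F)c3c2)[nH]c1=O`: < 0.0667 h (a limit of the assay)
- Compound 2 `CC(C)C(c1ccc(-c2ccc3cccc(F)c3c2)[nH]c1=O)N1CCN/C1=N\C#N`: 0.327 h

For the measured compounds named here, compound 2 holds the only true number in this small set, 0.327 h. Compound 1 gives < 0.0667 h, which is a limit of the assay and not a number.

The next compound to be read is compound 3 `CC(C)C(Cc1noc(=O)[nH]1)c1ccc(-c2ccc3cccc(F)c3c2)[nH]c1=O`. The change from compound 2 is a group of 7 heavy atoms (3 carbon, 2 nitrogen, 2 oxygen; one five-membered aromatic ring with 3 hetero atoms) in place of a group of 8 heavy atoms (4 carbon, 4 nitrogen; one five-membered non-aromatic ring with 2 hetero atoms), on a saturated chain carbon bound to an aromatic carbon and a saturated chain carbon. In short, a five-membered aromatic ring with 3 hetero atoms enters where a five-membered non-aromatic ring with 2 hetero atoms stood.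

Going by the values given here, only one measured step bears on this: an at least 4.9-fold higher number from compound 1 to compound 2 (0.69 log units; beyond the scatter). That step replaced a five-membered aromatic ring with a non-aromatic one, and the number rose beyond the scatter. Compound 3 returns to an aromatic ring, but a different one, so only part of that step is expected to reverse. The expected direction in this assay is therefore downward, though only slightly.

The estimated change is a 1.6-fold lower number from compound 2 to compound 3 (0.21 log units; within the scatter). For compound 3 the expected half-life is 0.2 h, with an estimated range from 0.07 h to 0.6 h.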

Compound 3, half-life: > 3 h
Compound 3 gave a limit, no number (the forecaster's own chance of this, stated with the estimate: 20%); at least 15-fold (1.17 log units) between middle value and limit.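

In this assay, an aromatic ring at this place does not by itself go with a short half-life: a five-membered aromatic ring with 3 hetero atoms in place of the five-membered non-aromatic ring with 2 hetero atoms gives an at least 9.1-fold higher number from compound 2 to compound 3 (0.96 log units; beyond the scatter). The comparison of the two aromatic rings, both on a saturated chain carbon two bonds along the chain from an aromatic carbon, gives an at least 44-fold higher number from compound 1 to compound 3 (1.65 log units; beyond the scatter), and among these three compounds this shows that the choice of ring counts for more than whether the ring is aromatic. Compound 3 stands at a limit of the assay and not at a number, and the full size of both steps remains unknown: the limit of > 3 h in this assay, at which 1 of the 3 values shown sits.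

Which feature of the entering ring goes with the longer half-life remains open, as three compounds cannot separate its ring atoms, its carbonyl and its hydrogen-bond acceptors from one another. Also open, from the compounds shown here alone, is whether a carboxylic acid or a primary amine on the same chain would give a half-life closer to that of compound 3 or of compound 1.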